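A few compounds are considered here, and "the series" means these few. Any claim that something is new, unique, unknown or untested is made for them only; others in the source may bear on it.

Two compounds have been measured in an assay on CHO cells for displacement of a labelled ligand from adenosine receptor A1 (Homo sapiens), with a stated time of 60 min, tested at 10 uM; on this read-out higher numbers stand for more inhibition at the one concentration tested (going by the name of the read-out) and lower numbers for less inhibition:

Compound 1, `CC(=O)C1=C(C)NC(=O)NC1c1ccco1`: 30%
Compound 2, `CC1=C(C(N)=O)C(c2ccco2)NC(=O)N1`: 2%

Compound 2 stands lowest of the two numbers, and its nearest neighbour is compound 1. For the measured compounds named here, the single measured step, a number 28 percentage points lower from compound 1 to compound 2 (beyond the scatter), came with amino in place of methyl on a carbonyl carbon and lies beyond the scatter.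

Compound 3, `CCCOC(=O)C1=C(C)NC(=O)NC1c1ccco1`, is still to be measured. It differs from compound 2 by propoxy in place of amino on a carbonyl carbon. Going by the values given here, the one step that bears on this is a number 28 percentage points lower from compound 1 to compound 2 (beyond the scatter), in which bringing in the amino group lowered the number. Compound 3 removes that amino group again, so the step of a number 23 percentage points higher from compound 2 to compound 3 (beyond the scatter) is expected to run upward, by roughly the size of the earlier step. A propoxy group is not the methyl group of compound 1, and nothing measured speaks to it, so the range is wide. Compound 3 is estimated at 25%, within 5% to 50%.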

Compound 3, a percentage reported as inhibition, at one concentration (the size of the read-out at that concentration, not a potency): 43%
Estimate against measurement, compound 3: 18 percentage points below; low and high end bracket the measured number.
By their numbers in this assay, from the lowest: compound 2; then compound 1; then compound 3.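

In this assay, swapping amino for propoxy on the carbonyl carbon gives a number 41 percentage points higher from compound 2 to compound 3 (beyond the scatter), so this position can move the number strongly upward as well as downward. Propoxy in place of methyl gives a number 13 percentage points higher from compound 1 to compound 3 (beyond the scatter), which shows that the gain goes beyond simply removing the amino group and returning to the level of compound 1: among the three groups, propoxy gives the highest number, with every step between them beyond the scatter. Nothing available explains why these groups rank in this order.

Still open, from the compounds shown here alone, is whether the rise follows the length of the chain or the oxygen that joins it to the carbonyl carbon, which a methoxy group, a butoxy group or a butyl chain at this place would help to separate. A reading at one concentration also leaves open how potent compound 3 is.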